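The compounds below may be only part of what the source reports. "The series", "measured", "known", "first", "only" and "open" are said of these compounds alone.

Compound 1 `C=CC1=C(C(=O)NCc2ccccc2)C(c2ccc(OC)c(OC)c2)OC1` was tested in a functional assay on SW480 cells (Homo sapiens) for cytotoxicity, read by MTT assay, with a stated time of 24 h; a higher number here means a weaker inhibitor, a lower number a stronger inhibitor; compound 1 gives a limit of the assay, > 100000 nM. Compound 2 `C=CC1=C(C(=O)NCc2ccccc2)C(c2ccc(OC)cc2)OC1` gives 39500 nM. Compound 3 `C=CC1=C(C(=O)O)C(c2ccc(F)cc2)OC1` gives a limit, > 100000 nM.

Among the measured compounds shown here, compound 2 thus holds the only real number here; the other two values are limits, as the limit of > 100000 nM in this assay, at which 2 of the 3 values shown sit, records. For the measured compounds named here, the one measured step, an at least 2.5-fold lower number from compound 1 to compound 2 (0.40 log units; beyond the scatter), concerns a group on the aromatic ring.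

Compound 4 `C=CC1=C(C(=O)NC(C)(C)C)C(c2ccc(OC)cc2)OC1` differs from compound 2 by tert-butyl in place of benzyl on an amide-type nitrogen. Going by the values given here, no measured step touches this amide nitrogen, so the only step gives no guide to it. The expected change from compound 2 to compound 4 is therefore none beyond the scatter, a 1.1-fold higher number from compound 2 to compound 4 (0.06 log units; within the scatter). Compound 4 is estimated at 45000 nM, between 15000 nM and 150000 nM.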

Compound 4, half-maximal inhibitory concentration: > 100000 nM
Compound 4 ended at the assay's limit; the forecaster's own chance of this, stated with the estimate: 30%; at least 2.2-fold (0.34 log units) between middle value and limit.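

Among the compounds shown here, on the amide nitrogen, which no earlier step touched, the group matters in this assay: tert-butyl in place of benzyl gives an at least 2.5-fold higher number from compound 2 to compound 4 (0.40 log units; beyond the scatter). Going by these compounds, compound 4 gives only a limit, so the full size of this step stays unknown. Benzyl alone does not secure a measurable number either, as compound 1 also carries it, and the series now crowds at one ceiling: the limit of > 100000 nM in this assay, at which 3 of the 4 values shown sit.

The compounds shown leave open whether the benzyl ring itself counts, which a cyclohexylmethyl group on this nitrogen could test. They also leave open how a longer chain, such as phenethyl, would behave there.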